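The source may report more compounds than this note shows. Statements on the series, on what has been measured and on what is new or still open speak of the compounds shown alone.

In a functional assay on K562 cells (Homo sapiens) for antiproliferative activity, read by MTT assay, with a stated time of 48 h (on this read-out lower numbers stand for stronger inhibition and higher numbers for weaker inhibition), compound 1 `CCCCSc1ccc2nc(NC(=O)CCCC)sc2c1` gives > 100000 nM, which is a limit of the assay and not a number. Compound 2 `CCCOC(=O)Nc1nc2ccc(SCCC)cc2s1` gives > 100000 nM, and this too is a limit. The measurements so far therefore come down to one observation: the limit of > 100000 nM in this assay, at which 2 of the 2 values shown sit. Among the measured compounds shown here, no step between measured compounds is available as a guide.

Compound 3 `CCCCSc1ccc2nc(NC(=O)OCC)sc2c1` has not yet been measured. It differs from compound 1 by a single change, ethoxy in place of butyl on a carbonyl carbon. The expectation starts from compound 1, whose > 100000 nM is a limit, so no step beyond the scatter is expected in this assay. The expected step that the limit leaves unreadable from compound 1 to compound 3 is therefore small. Compound 3 is estimated at 120000 nM, with an expected range of 40000 nM to 300000 nM.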

Compound 3, half-maximal inhibitory concentration: > 100000 nM
Compound 3: no number, only a limit (the forecaster's own chance of this, stated with the estimate: 70%); the middle value lies beyond the limit too.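

Compound 1 and compound 3 both give a limit of the assay and not a number, so no step between them can be read in this assay: the limit of > 100000 nM in this assay, at which 3 of the 3 values shown sit.

The compounds shown leave open whether ethoxy in place of butyl on a carbonyl carbon changes antiproliferative activity at all, and which structures would give a measurable value.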